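A few compounds are considered here, and "the series" means these few. Any claim that something is new, unique, unknown or untested is made for them only; others in the source may bear on it.

Measured compounds:
- compound 1, `O=C(Nc1ncc(Cc2ccc(Cl)cc2)s1)c1cccs1`: > 50000 nM
- compound 2, `O=C(Nc1ncc(Cc2ccc(Br)cc2)s1)c1ccc2ccccc2c1`: > 50000 nM
- compound 3, `CCN(CC)C(=O)Nc1ncc(C(Oc2ccc3cc(Br)ccc3c2)c2ccc(Cl)cc2)s1`: "not toxic" (no number reported)

The three compounds share a core and were all tested in an ADME assay on HepG2 2.2.15 cells (Homo sapiens) for cytotoxicity; a lower number here means that less compound is tolerated, a higher number that more compound is tolerated. For compound 1 the value > 50000 nM is a limit of the assay, not a number. For compound 2 the value > 50000 nM is likewise a limit. Compound 3 is reported in this assay only as "not toxic" (no number reported), with no number attached, so it stands among the two other values as a third entry that gives no figure; the limit of > 50000 nM in this assay, at which 2 of the 3 values shown sit, is the only fixed point in this set.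

Compound 4, `O=S(=O)(Nc1ncc(C(Oc2ccc3cc(Br)ccc3c2)c2ccc(Cl)cc2)s1)c1ccc(Cl)cc1`, has not yet been measured in this assay. It differs from compound 3 in one place: (4-chlorophenyl)sulfonyl in place of diethylcarbamoyl on a nitrogen on an aromatic ring. Among the measured compounds shown here, no step between measured compounds exists that would show how such a change moves the read-out, so the direction of the step is unknown. Compound 3 is recorded as "not toxic" (no number reported). As compound 1 and compound 2 sit at the limit, the step from compound 3 to compound 4 in this assay is expected to stay within the scatter.

Compound 4 is therefore expected to give about 50000 nM in this assay, in a range from 15000 nM to 150000 nM, with a good chance that only a limit is reported.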

Compound 4, half-maximal cytotoxic concentration: "not toxic" (no number reported)
Compound 4 has no reported number here; there is nothing to compare the estimate with.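

Compound 3 and compound 4 are both reported in this assay only as "not toxic", with no number attached, so no step can be read between them. The compounds shown leave open at what concentration any of them would become toxic to these cells, as the only figure in the set is a limit: the limit of > 50000 nM in this assay, at which 2 of the 4 values shown sit.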